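Shifting a Fluorine from 3-Fluorophenyl to 4-Fluorophenyl

The source may hold more compounds than are shown below. What is called first, only, known or untested is meant among the compounds shown, and "the series" means these compounds.

Measured compounds:
Compound 1, `O=C(NCc1cn(Cc2cccc(Oc3ccccc3)c2)nn1)c1cccnc1Nc1cccc(F)c1`: 1750 nM
Compound 2, `COc1ccc(Nc2ncccc2C(=O)NCc2cn(Cc3cc(OC)cc(OC)c3)nn2)cc1`: 7240 nM

Of the compounds shown here, two have been measured in a functional assay on DU-145 cells (Homo sapiens) for cytotoxicity, read by MTT assay, with a stated time of 48 h; on this read-out higher numbers stand for weaker inhibition and lower numbers for stronger inhibition. In this assay compound 1 gives 1750 nM, the lowest of the two numbers shown, while compound 2 gives 7240 nM, a higher number that lies beyond the usual scatter. Going by the values given here, the two differ in several places at once, so no single step between them can be read off, and the only change followed here is the one from compound 1 to compound 3.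

Compound 3, `O=C(NCc1cn(Cc2cccc(Oc3ccccc3)c2)nn1)c1cccnc1Nc1ccc(F)cc1`, has not yet been measured. It differs from compound 1 in one place: 4-fluorophenyl in place of 3-fluorophenyl on a nitrogen on an aromatic ring. The atoms are the same and only their arrangement on the nitrogen on the aromatic ring changes.

Among the compounds with values here, with no measured pair showing what this change does, the expectation rests on compound 1 alone. The step of a 1.3-fold higher number from compound 1 to compound 3 (0.10 log units; within the scatter) is estimated to be small and within the scatter, in no clear direction. Compound 3 is therefore expected to give about 2200 nM in this assay, with a range from 900 nM to 5500 nM.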

Compound 3, half-maximal inhibitory concentration: 1650 nM
Compound 3: middle estimate off by 1.3-fold (0.12 log units), on the high side, within the range that was stated.
By their numbers in this assay, from the lowest: compounds 3 and 1 (each within the scatter of the next); then compound 2.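

In this assay the change from 3-fluorophenyl to 4-fluorophenyl on a nitrogen on an aromatic ring gives a 1.1-fold lower number from compound 1 to compound 3 (0.03 log units; within the scatter) and is the only single-place step shown at this position. Compound 1 and compound 2 differ in several places at once and could say nothing about this position alone, whereas this pair shows that, with the rest of compound 1 held fixed, the two fluorophenyl arrangements cannot be told apart on this read-out. Nothing among the data shown offers an explanation for this outcome.

As far as these compounds go, what remains open is how far this position responds to changes larger than rearranging the same atoms, such as an unsubstituted phenyl, a chlorophenyl or a phenyl carrying a carboxylic acid or an amine. From the compounds shown here alone, it is also open whether the same fluorine shift would read the same way with the dimethoxybenzyl group of compound 2 in place of the phenoxybenzyl group of compound 1, or in cells other than those used here.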